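The source may report more compounds than this note shows. Statements on the series, on what has been measured and on what is new or still open speak of the compounds shown alone.

Three compounds share one core and differ only in the ring attached to the outer benzene. Compound 1 `CNC(=O)N1CCCc2ccc(NC(=O)c3ccc(-c4cc[nH]n4)cc3)cc21` carries a 1H-pyrazol-3-yl group and gives 92.5% in a functional assay on MV4-11 cells (Homo sapiens) for antiproliferative activity, with a stated time of 6 days, tested at 1.56 uM; on this read-out higher numbers stand for a stronger effect at the one concentration tested and lower numbers for a weaker effect. Compound 2 `CNC(=O)N1CCCc2ccc(NC(=O)c3ccc(-c4ccccc4)cc3)cc21` carries a phenyl group and gives 19.7%. Compound 3 `CNC(=O)N1CCCc2ccc(NC(=O)c3ccc(-c4ccncc4)cc3)cc21` carries a pyridin-4-yl group and gives 37.6%, which places it second of the three: it sits a number 17.9 percentage points higher from compound 2 to compound 3 (beyond the scatter) and a number 54.9 percentage points lower from compound 1 to compound 3 (beyond the scatter).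

Compound 4 `CNC(=O)N1CCCc2ccc(NC(=O)c3ccc(-c4ccn(S(C)(=O)=O)n4)cc3)cc21` has not been measured. Its change from compound 3 is 1-(methylsulfonyl)-1H-pyrazol-3-yl in place of pyridin-4-yl on an aromatic carbon. This brings back the five-membered ring of compound 1, now carrying a methylsulfonyl group in place of the ring hydrogen. Going by the values given here, the steps that bear on it are a number 54.9 percentage points lower from compound 1 to compound 3 (beyond the scatter) and a number 72.8 percentage points lower from compound 1 to compound 2 (beyond the scatter), both large. Since the ring type of compound 1 returns, a rise is expected, though the hydrogen-bond donor counted in compound 1 is absent in compound 4, so the size is uncertain. The expected step is a number 22.4 percentage points higher from compound 3 to compound 4 (beyond the scatter). Compound 4 is therefore estimated at 60%, within 25% to 92%.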

Compound 4, a percentage reported as inhibition, at one concentration (the size of the read-out at that concentration, not a potency): 8.81%
The estimate for compound 4 lay 51.2 percentage points above the measured number, outside the stated range (below it).
By their numbers in this assay, from the lowest: compound 4; then compound 2; then compound 3; then compound 1.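

Keeping the five-membered ring does not by itself keep the effect in this assay: methylsulfonyl in place of the hydrogen on the ring nitrogen gives a step of a number 83.7 percentage points lower from compound 1 to compound 4 (beyond the scatter), the largest printed so far in this set. The substituted ring also falls short of both six-membered rings, with a number 28.8 percentage points lower from compound 3 to compound 4 (beyond the scatter) against pyridin-4-yl and a number 10.9 percentage points lower from compound 2 to compound 4 (beyond the scatter) against phenyl, so at this position the ring type alone does not set the order. No measurement at hand explains this drop.

The compounds shown cannot separate the loss of the hydrogen on the ring nitrogen from the presence of the methylsulfonyl group itself. A plain methyl group on that nitrogen would be one way to pull these two changes apart.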